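Aryl swap on the ring amine: what compound 4 may give

The compounds below may be only part of what the source reports. "The series", "measured", "known", "first", "only" and "open" are said of these compounds alone.

Compound 1, `Nc1scc(CN2CCN(c3ccc(Cl)cc3F)CC2)c1C(=O)c1ccc(Cl)cc1`, gives -9.2% in a functional assay on CHO cells with adenosine receptor A1 (Homo sapiens) as the target, read by cAMP accumulation and immunoassay, with a stated time of 6 min, tested at 0.01 uM; on this read-out higher numbers stand for a weaker effect at the one concentration tested and lower numbers for a stronger effect.
Compound 2, `Nc1scc(CN2CCN(c3ccc([N+](=O)[O-])cc3)CC2)c1C(=O)c1ccc(Cl)cc1`, gives -12%.
Compound 3, `Nc1scc(CN2CCN(c3ccccc3F)CC2)c1C(=O)c1ccc(Cl)cc1`, gives 2.1%.

Compound 3 has the highest number of the three: the step of a number 11.3 percentage points higher from compound 1 to compound 3 (beyond the scatter) and the step of a number 14.1 percentage points higher from compound 2 to compound 3 (beyond the scatter) both lie beyond the scatter, while a number 2.8 percentage points lower from compound 1 to compound 2 (within the scatter) does not. Compound 4, `Nc1scc(CN2CCN(c3cccc(Cl)c3)CC2)c1C(=O)c1ccc(Cl)cc1`, differs from compound 3 by 3-chlorophenyl in place of 2-fluorophenyl on an amine nitrogen in a ring. The two steps that change the aryl on the ring nitrogen, a number 2.8 percentage points lower from compound 1 to compound 2 (within the scatter) and a number 14.1 percentage points higher from compound 2 to compound 3 (beyond the scatter), were small or modest, so only a modest step is expected. Compound 4 is expected to sit a little lower, with a number 6.1 percentage points lower from compound 3 to compound 4 (within the scatter). For compound 4 the estimate is -4%, between -18% and 10%.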

Compound 4, a percentage reported as activity, at one concentration (the size of the read-out at that concentration, not a potency): -3.1%
For compound 4 the middle estimate is 0.9 percentage points below the measured one; the measured number falls inside the stated range.
By their numbers in this assay, from the lowest: compounds 2, 1, 4 and 3 (each within the scatter of the next, the first and the last beyond it).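

In this assay the change to 3-chlorophenyl gives a number 5.2 percentage points lower from compound 3 to compound 4 (within the scatter), together with a number 6.1 percentage points higher from compound 1 to compound 4 (within the scatter) and a number 8.9 percentage points higher from compound 2 to compound 4 (within the scatter). Compound 4 therefore lies within the scatter of all three earlier compounds, even though compound 2 and compound 3 lie beyond the scatter of each other, so it does not separate from any of the other aryl groups on this ring nitrogen. Nothing available accounts for these numbers. From the compounds shown here alone, whether a pyridyl ring, a benzyl group or an acetyl group on this nitrogen would stay within the same narrow band remains open.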